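Swapping the phenyl ring on a prostaglandin D2 receptor binder

This account rests on a few compounds, and the source may have more. Where it says the series, first, only, none or still open, it means among the compounds named here.

Compound 1, `O=C(O)Cc1sc(C(c2ccc(F)cc2)c2ccc(F)cc2)nc1-c1ccccc1`: 16 nM
Compound 2, `O=C(O)Cc1sc(C(c2ccccc2)c2ccc(F)c(F)c2)nc1-c1ccc(F)cc1`: 10 nM

Of the compounds shown here, two have been measured in an in vitro assay on HEK385-7 cells for displacement of a labelled ligand from prostaglandin D2 receptor 2 (Homo sapiens); a higher number here means a weaker inhibitor, a lower number a stronger inhibitor. Compound 1 gives 16 nM, the higher of the two numbers. Compound 2 gives 10 nM, which lies within the usual scatter of repeated measurements, so the two compounds cannot be told apart on these values. Compound 3, `N#Cc1cc(-c2nc(C(c3ccc(F)cc3)c3ccc(F)cc3)sc2CC(=O)O)ccc1F`, has not yet been measured. It differs from compound 1 in one place: 3-cyano-4-fluorophenyl in place of phenyl on an aromatic carbon. For the measured compounds named here, no pair of measured compounds differs by exactly this change, so there is no measured step from which to read its size. Given that the two measured values sit close together, the step from compound 1 to compound 3 is expected to be small, a 1.5-fold lower number from compound 1 to compound 3 (0.16 log units; within the scatter), most likely not beyond the scatter. The value estimated for compound 3 in this assay is 11 nM, with a range from 4 nM to 35 nM.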

Compound 3, half-maximal inhibitory concentration: 57 nM
Estimate against measurement, compound 3: 5.2-fold (0.71 log units) below; measured number outside the range, above it.
By their numbers in this assay, from the lowest: compounds 2 and 1 (each within the scatter of the next); then compound 3.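

In this assay, this position responds to what it carries: on the aromatic carbon next to the ring nitrogen, 3-cyano-4-fluorophenyl in place of phenyl gives a 3.6-fold higher number from compound 1 to compound 3 (0.55 log units; beyond the scatter), a modest move towards a weaker inhibitor. The two earlier compounds could not show this, as they differ in more than one place and their values lie within the scatter of each other. No measurement here explains the loss, so its cause stays unknown.

From the compounds shown here alone, because compound 3 brings in the nitrile and the fluorine together, the share of each in this step remains open. Going by these compounds, it is also open whether a ring carrying only the nitrile, only the fluorine, or a methoxy group instead would stay as close to compound 1 as the plain phenyl baseline allows.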